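This account rests on a few compounds, and the source may have more. Where it says the series, first, only, none or still open, it means among the compounds named here.

Measured in a physicochemical assay for solubility, at pH 7.4; on this read-out higher numbers stand for higher solubility and lower numbers for lower solubility:
Compound 1 `Cc1cc(NC(=O)Nc2ccccc2C(C)(C)C)c2ccccc2n1` gives 100 nM.
Compound 2 `CSc1ccccc1NC(=O)Nc1cc(C)nc2ccccc12` gives 21000 nM.
Compound 3 `COc1ccccc1NC(=O)Nc1cc(C)nc2ccccc12` gives 100 nM.

Compound 3 stands level with compound 1 at the digits shown, and together these two are the lowest of the three numbers; compound 2 sits far above, as the step of a 210-fold lower number from compound 2 to compound 3 (2.32 log units; beyond the scatter) shows when read the other way.

Compound 4 `Cc1cc(NC(=O)Nc2ccccc2[N+](=O)[O-])c2ccccc2n1` differs from compound 3 in one place: nitro in place of methoxy on an aromatic carbon. The group sits on an aromatic carbon of a six-membered aromatic ring of carbon only, ortho to a large group.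

For the measured compounds named here, two measured steps touch the same position. From compound 1 to compound 3, no change at the digits printed from compound 1 to compound 3 (within the scatter), while a 210-fold lower number from compound 2 to compound 3 (2.32 log units; beyond the scatter). Going by the values given here, neither step involves a nitro group, so no measured step bears directly on the change to compound 4. With only that to go on, the expected step is a 2.0-fold higher number from compound 3 to compound 4 (0.30 log units; within the scatter), which is no change beyond the scatter, with wide uncertainty in both directions.

Compound 4 is therefore expected to give about 200 nM in this assay, with a range from 40 nM to 3000 nM.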

Compound 4, solubility: 200 nM
For compound 4 middle estimate and measured number coincide at the digits printed; low and high end bracket the measured number.
By their numbers in this assay, from the lowest: compounds 1, 3 and 4 (each within the scatter of the next); then compound 2.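

In this assay, nitro on this aromatic carbon, ortho to a large group, behaves like the two groups at the low end: the data give a 2.0-fold higher number from compound 3 to compound 4 (0.30 log units; within the scatter) and a 2.0-fold higher number from compound 1 to compound 4 (0.30 log units; within the scatter). Methylsulfanyl, by contrast, keeps its large lead over this new group, with a 110-fold lower number from compound 2 to compound 4 (2.02 log units; beyond the scatter). Of the four groups now seen at this position, three differ widely in name and size yet stay within the scatter of one another, and methylsulfanyl in compound 2 is the sole exception.

No measured property is available to explain why methylsulfanyl alone stands apart. Going by these compounds, whether an amine, a carboxylic acid or a longer chain such as ethylsulfanyl would follow compound 2 or stay with the other three remains open.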